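A few compounds are considered here, and "the series" means these few. Any claim that something is new, unique, unknown or untested is made for them only; others in the source may bear on it.

Compound 1 `CCCCCCCCc1ccc(CCC(CO)(CO)NC(=O)CCCCC)c2ccccc12`: 20300 nM
Compound 2 `CCCCCCCCc1ccc(CCC(CO)(CO)NC(=O)CCCCCCC)c2ccccc12`: 22000 nM
Compound 3 `CCCCCCCCc1ccc(CCC(CO)(CO)NC(=O)C(C)CC)c2ccccc12`: 25600 nM

These three compounds share one core and differ only in the acyl group joined to the amide. In a functional assay on HT-29 cells (Homo sapiens) for antiproliferative activity, read by sulforhodamine B assay, with a stated time of 72 h (a lower number here means a stronger inhibitor, a higher number a weaker inhibitor), compound 2 gives the second highest of the three numbers; its nearest neighbour is compound 1, the step being a 1.1-fold higher number from compound 1 to compound 2 (0.03 log units; within the scatter), and its furthest is compound 3, with a 1.2-fold higher number from compound 2 to compound 3 (0.07 log units; within the scatter). The remaining measured step, a 1.3-fold higher number from compound 1 to compound 3 (0.10 log units; within the scatter), is also within the scatter, so the three values are indistinguishable on this evidence.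

Compound 4 `CCCCCCCOc1ccc(CCC(CO)(CO)NC(=O)CCCCCCC)c2ccccc12` is not yet measured. It differs from compound 2 in heptyloxy in place of octyl on an aromatic carbon. Within the data shown here, none of the measured steps touches this part of the molecule; all three alter the acyl group on the carbonyl carbon and all stay within the scatter. Among the measured compounds shown here, no measured step therefore bears directly on the change, and the expectation rests on the weak effect of structural variation seen so far: a step of no change at the digits printed from compound 2 to compound 4 (within the scatter) in this assay, that is, no change beyond the scatter, is expected. Going by these compounds, compound 4 is estimated at 22000 nM, with a range from 8000 nM to 60000 nM, the width reflecting that this position is untested.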

Compound 4, half-maximal inhibitory concentration: 18800 nM
The estimate for compound 4 lay 1.2-fold (0.07 log units) above the measured number; the measured number falls inside the stated range.
By their numbers in this assay, from the lowest: compounds 4, 1, 2 and 3 (each within the scatter of the next).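

Compound 2 and compound 4 give the first test of the chain on the aromatic carbon para to a large group, and in this assay the exchange of octyl for heptyloxy is a 1.2-fold lower number from compound 2 to compound 4 (0.07 log units; within the scatter) of the shared core. The earlier steps shown here changed only the acyl group, so this adds a second part of the molecule where a change stays within the scatter, here one that keeps the count of heavy atoms and adds an oxygen and a hydrogen-bond acceptor. Nothing measured here explains this result.

Both chains at this position have the same heavy-atom count, so a much shorter chain, or one ending in an amine or a carboxylic acid, remains an open case. Also open, going by these compounds, is whether an acyl group such as benzoyl would move the number beyond the scatter.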